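The source may hold more compounds than are shown below. What is called first, only, known or untested is meant among the compounds shown, and "the series" means these compounds.

Of the compounds shown here, three sharing one core have been measured in an assay on membranes from HEK293 cells for displacement of a labelled ligand from adenosine receptor A2b (Homo sapiens), read by scintillation counting, with a stated time of 30 min, tested at 1 uM; on this read-out lower numbers stand for less inhibition and higher numbers for more inhibition at the one concentration tested (going by the name of the read-out). Compound 1 `CCNC(=O)C1=C(C)NC(=O)NC1c1ccoc1` gives 2%, and compound 2 `CCSC(=O)C1=C(C)NC(=O)NC1c1ccoc1` gives 1%; the step of a number 1 percentage points lower from compound 1 to compound 2 (within the scatter) is too small to carry meaning. Compound 3 `CCC(CC)OC(=O)C1=C(C)NC(=O)NC1c1ccoc1` gives 28%, the highest of the three numbers, with steps a number 26 percentage points higher from compound 1 to compound 3 (beyond the scatter) and a number 27 percentage points higher from compound 2 to compound 3 (beyond the scatter), both beyond the scatter but modest in size.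

Compound 4 `CC1=C(C(=O)OC2CCCCC2)C(c2ccoc2)NC(=O)N1` has not been measured. It differs from compound 3 by cyclohexyl in place of pentan-3-yl on an oxygen next to a carbonyl group. The measured steps all concern what is attached at the carbonyl carbon itself, exchanging an ethylamino or ethylsulfanyl group for an oxygen-linked group; none of them compares two different groups on an oxygen next to a carbonyl group, which is the kind of change made here. Compound 3 shows that an oxygen-linked branched alkyl group is compatible with measurable inhibition, and cyclohexyl resembles pentan-3-yl in size. The step of a number 2 percentage points higher from compound 3 to compound 4 (within the scatter) is therefore expected to stay within the scatter. Compound 4 is estimated at 30%, with a plausible range from 10% to 55%.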

Compound 4, a percentage reported as inhibition, at one concentration (the size of the read-out at that concentration, not a potency): 4%
For compound 4 the middle estimate is 26 percentage points above the measured one, and the stated range ends above it.
By their numbers in this assay, from the lowest: compounds 2, 1 and 4 (each within the scatter of the next); then compound 3.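

Changing the group on an oxygen next to a carbonyl group matters in this assay: a number 24 percentage points lower from compound 3 to compound 4 (beyond the scatter), so an oxygen link at the carbonyl carbon does not by itself secure the higher number of compound 3. The cyclohexyloxy group also gives no separation from the other two groups on that carbon, with a number 3 percentage points higher from compound 2 to compound 4 (within the scatter) and a number 2 percentage points higher from compound 1 to compound 4 (within the scatter), leaving compound 3 alone among the four. No evidence here accounts for the difference between pentan-3-yl and cyclohexyl.

This single pair cannot tell whether the ring or the extra carbon goes with the lower number, since cyclohexyl differs from pentan-3-yl in both. It also leaves open how other groups on the same oxygen, such as cyclopentyl, tert-butyl or a straight pentyl chain, would read.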